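Cyclohexyl to Trifluoromethylphenyl: Expected Cytotoxicity of Compound 3

The source may report more compounds than this note shows. Statements on the series, on what has been measured and on what is new or still open speak of the compounds shown alone.

Compound 1 `COc1cc(NC(C)CCCNC(=O)NNC(=O)/C=C/c2cccc(C(F)(F)F)c2)c2ncccc2c1` was tested in an ADME assay on L6 cells (Rattus norvegicus) for cytotoxicity, read by resazurin assay, with a stated time of 70 h (on this read-out lower numbers stand for stronger inhibition and higher numbers for weaker inhibition), and gave 10600 nM. Compound 2 `COc1cc(NC(C)CCCNC(=O)NNC(=O)NC2CCCCC2)c2ncccc2c1` is recorded in this assay as "not determined" (no result reported), so it stands at no number there. Compound 3 `COc1cc(NC(C)CCCNC(=O)NNC(=O)Nc2cccc(C(F)(F)F)c2)c2ncccc2c1` differs from compound 2 by 3-(trifluoromethyl)phenyl in place of cyclohexyl on an amide-type nitrogen. Among the measured compounds shown here, with no measured step at hand, no shift beyond the usual scatter can be foreseen for the change from compound 2 to compound 3 in this assay. Since compound 1, with the same core, gave 10600 nM, weak cytotoxicity is expected. Compound 3 is expected to give about 15000 nM in this assay, within 5000 nM to 50000 nM.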

Compound 3, half-maximal inhibitory concentration: 32100 nM
Beside the measured number, compound 3's estimate is 2.1-fold (0.33 log units) below it; low and high end bracket the measured number.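

In this assay, among the compounds shown here, the one readable step is a 3.0-fold higher number from compound 1 to compound 3 (0.48 log units; beyond the scatter) and it goes towards weaker inhibition. With the 3-(trifluoromethyl)phenyl group present in both compounds, it shows that exchanging 2-(3-(trifluoromethyl)phenyl)ethenyl for (3-(trifluoromethyl)phenyl)amino on a carbonyl carbon moves the number beyond the scatter. The step from compound 2 to compound 3 cannot be read, and no measurement at hand accounts for the shift.

From the compounds shown here alone, how the cyclohexylamino group of compound 2 compares with (3-(trifluoromethyl)phenyl)amino in this assay stays open. So does whether a carboxylic acid or a morpholine in place of 3-(trifluoromethyl)phenyl would keep the number this high.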